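Replacing Fluoro with Isopropoxy on a Shared Amide Scaffold

A few compounds are considered here, and "the series" means these few. Any claim that something is new, unique, unknown or untested is made for them only; others in the source may bear on it.

Of the compounds shown here, three sharing one core have been tested in a functional assay on HEK293 cells for agonist activity at D(4) dopamine receptor (Homo sapiens), read by FLIPR; a lower number here means a smaller maximal response, a higher number a larger maximal response. Compound 1 `CCc1cccc(NC(=O)CN2CCC(c3cccc[n+]3[O-])CC2)c1` gives 62%, compound 2 `Cc1cc(C)cc(NC(=O)CN2CCC(c3cccc[n+]3[O-])CC2)c1` gives 76%, and compound 3 `O=C(CN1CCC(c2cccc[n+]2[O-])CC1)Nc1cccc(F)c1` gives 70%. Compound 3 stands second highest of the three numbers, and its steps to both neighbours, a number 6 percentage points lower from compound 2 to compound 3 (within the scatter) and a number 8 percentage points higher from compound 1 to compound 3 (within the scatter), lie within the scatter, so the three are not clearly separated. Within the data shown here, only the step of a number 14 percentage points higher from compound 1 to compound 2 (beyond the scatter) exceeds the scatter.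

Compound 4 `CC(C)Oc1cccc(NC(=O)CN2CCC(c3cccc[n+]3[O-])CC2)c1` differs from compound 3 by a single change: isopropoxy in place of fluoro on an aromatic carbon. Among the measured compounds shown here, the closest precedent is the swap of ethyl for fluoro on the same aromatic carbon, which produced a number 8 percentage points higher from compound 1 to compound 3 (within the scatter), within the scatter. For the measured compounds named here, no measured compound carries an isopropoxy group, so nothing shows how a larger group with an oxygen behaves here. Given that precedent, a small step in this assay is expected.

Compound 4 is therefore expected to reach about 68%, with a range from 50% to 85%. For compound 4 this estimate corresponds to a number 2 percentage points lower from compound 3 to compound 4 (within the scatter).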

Compound 4, largest response reached (reported as efficacy), in percent of the reference or control that the assay uses: 48%
For compound 4 the middle estimate is 20 percentage points above the measured one, and the stated range ends above it.
By their numbers in this assay, from the lowest: compound 4; then compounds 1, 3 and 2 (each within the scatter of the next, the first and the last beyond it).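

In this assay, this aromatic carbon proves sensitive to what it carries: fluoro and ethyl stay within the scatter of each other, whereas isopropoxy gives a clearly smaller maximal response, with a number 22 percentage points lower from compound 3 to compound 4 (beyond the scatter) and a number 14 percentage points lower from compound 1 to compound 4 (beyond the scatter). Among these compounds, both steps point the same way and lie beyond the scatter, so isopropoxy, with four heavy atoms and one hydrogen-bond acceptor, is the first change at this place that separates two compounds. No supporting data are available to explain this drop.

The compounds shown leave open whether the oxygen or the branched carbons matter more, a question that methoxy and isopropyl groups on this carbon could help separate. They also leave open how an amine or a carboxylic acid would behave here.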